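This account rests on a few compounds, and the source may have more. Where it says the series, first, only, none or still open, it means among the compounds named here.

Working notes on the series. Three compounds have numbers in a functional assay on SK-OV-3 cells (Homo sapiens) for cytotoxicity, read by MTT assay, with a stated time of 48 h; a higher number here means a weaker inhibitor, a lower number a stronger inhibitor: compound 1 `CN(C)CCCCCN(C)C1=Nc2ccccc2C(CC(=O)NCc2ccccc2)N1c1ccc(-c2ccccn2)cc1` gives 2410 nM, compound 2 `CN(C)CCCCN(C)C1=Nc2ccccc2C(CC(=O)NCc2ccccc2)N1c1ccc(-c2ccccc2)cc1` gives 9780 nM, and compound 3 `Cc1ccc(CNC(=O)CC2c3ccccc3N=C(N3CCN(CCN(C)C)CC3)N2c2ccc(-c3ccccc3)cc2)cc1` gives 2330 nM. Compound 3 has the lowest of the three numbers; compound 1 sits within the scatter of it, and only compound 2 lies beyond the scatter. For the measured compounds named here, no single-point step between measured compounds is available, so the change to compound 4 `COc1ccc(CNC(=O)CC2c3ccccc3N=C(N3CCN(CCN(C)C)CC3)N2c2ccc(-c3ccccc3)cc2)cc1` stands on its own: methoxy in place of methyl on an aromatic carbon. Such a change is expected to move the number in this assay little, with no step beyond the scatter in either direction; the expected step is a 1.1-fold higher number from compound 3 to compound 4 (0.05 log units; within the scatter). Compound 4 is estimated at 2600 nM, with a range from 1100 nM to 6500 nM.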

Compound 4, half-maximal inhibitory concentration: 2470 nM
Estimate against measurement, compound 4: 1.1-fold (0.02 log units) above; measured number inside the range.
By their numbers in this assay, from the lowest: compounds 3, 1 and 4 (each within the scatter of the next); then compound 2.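

For the compounds shown here, this is the first single-place comparison. On an aromatic carbon para to a large group, methoxy in place of methyl gives a 1.1-fold higher number from compound 3 to compound 4 (0.03 log units; within the scatter) in this assay, so the added oxygen and its hydrogen-bond acceptor bring no readable change at this position. No measured evidence on the cause accompanies this result.

On these data alone, only these two groups are compared here, so it remains open whether a carboxylic acid or an amine at this position would also stay within the scatter. As far as these compounds go, whether the same change would read alike with the other side chains of compound 1 or compound 2 also remains open.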